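The source may hold more compounds than are shown below. What is called first, only, known or untested is meant among the compounds shown, and "the series" means these compounds.

Measured compounds so far:
compound 1 `CS(=O)(=O)c1ccc(C(=O)Nc2ccc(Cl)c(-c3nnc4c(Cl)cccn34)c2)cc1` – in a functional assay on MDA-MB-231 cells (Homo sapiens) for antiproliferative activity, read by MTT assay, with stated times of 72 h and 4 h (on this read-out lower numbers stand for stronger inhibition and higher numbers for weaker inhibition), compound 1 gives > 100000 nM, which is a limit of the assay and not a number.
compound 2 `O=C(Nc1ccc(Cl)c(-c2nnc3c(Cl)cccn23)c1)c1ccon1` – in this assay compound 2 gives > 100000 nM, again a limit rather than a number.
compound 3 `O=C(Nc1ccc(Cl)c(-c2nnc3c(Cl)cccn23)c1)c1ccccc1` – in this assay compound 3 gives 58200 nM.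

Within the data shown here, compound 3 therefore stands as the only compound of the three with a real number; the other two sit at the limit (the limit of > 100000 nM in this assay, at which 2 of the 3 values shown sit). The next compound, compound 4 `CS(=O)(=O)c1cccc(C(=O)Nc2ccc(Cl)c(-c3nnc4c(Cl)cccn34)c2)c1`, is built from compound 3 by one change: methylsulfonyl in place of hydrogen on an aromatic carbon. Among the measured compounds shown here, the closest measured step is the one from compound 1, which also carries a methylsulfonyl on the same phenyl ring, to compound 3: an at least 1.7-fold lower number from compound 1 to compound 3 (0.23 log units; that floor lies within the scatter). Read in the other direction, putting a methylsulfonyl back onto the phenyl pushed the number up out of the readable range. The step of an at least 1.7-fold lower number from compound 2 to compound 3 (0.23 log units; that floor lies within the scatter) concerns a different ring and bears only loosely here. On this basis the number for compound 4 is expected to rise again by a 2.6-fold higher number from compound 3 to compound 4 (0.41 log units; beyond the scatter), quite possibly beyond the limit. The estimate for compound 4 in this assay is 150000 nM, within a range from 40000 nM to 500000 nM.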

Compound 4, half-maximal inhibitory concentration: > 100000 nM
Compound 4: only a limit was reported; the forecaster's own chance of this, stated with the estimate: 60%; the middle value lies beyond the limit too.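

Compound 4 shows that, in this assay, a methylsulfonyl group on the phenyl ring of compound 3 ends at the limit of the assay not only as the 4-(methylsulfonyl)phenyl of compound 1 but also as the 3-(methylsulfonyl)phenyl, so moving the group to this position does not restore a readable number. Among these compounds, the one step that can be read is an at least 1.7-fold higher number from compound 3 to compound 4 (0.23 log units; that floor lies within the scatter), and it is a floor rather than a measured size, while the steps joining compound 4 to compound 1 and to compound 2 cannot be read, as both ends of each are limits. Compound 3 therefore remains the only compound with a real number, which leaves little to compare: the limit of > 100000 nM in this assay, at which 3 of the 4 values shown sit.

From the compounds shown here alone, it remains open whether another group at this position of the phenyl ring, such as an amine or a methoxy group, would give a lower number than compound 3 at 58200 nM. Going by these compounds, it also remains open how far past the limit compound 1, compound 2 and compound 4 actually lie, and so whether they differ from one another at all.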